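The compounds below may be only part of what the source reports. "The series", "measured", "known", "first", "only" and "open" are said of these compounds alone.

Working notes on the series, opening.

The series is built on a shared core; compound 1 `Nc1cc(-c2ccccc2)ccc1NC(=O)c1ccc(CNc2nccc(-c3cccnc3)n2)cc1` carries a phenyl substituent on the aminoanilide ring, compound 2 `CC(C)(C)[Si](C)(C)OCc1ccc(NC(=O)c2ccc(CNc3nccc(-c4cccnc4)n3)cc2)c(N)c1` a silyl-protected hydroxymethyl group at that position, and compound 3 `Nc1cc2ccccc2cc1NC(=O)c1ccc(CNc2nccc(-c3cccnc3)n2)cc1` fuses the ring into a naphthalene. In an assay for inhibition of histone deacetylase 8 (Homo sapiens), read by fluorescence, with stated times of 15 min and 60 min (a lower number here means a stronger inhibitor, a higher number a weaker inhibitor), compound 1 gives only a limit, > 20000 nM. In this assay compound 2 also gives only a limit, > 20000 nM. Compound 3 likewise stands at a limit in this assay, > 20000 nM. Among the measured compounds shown here, the one step between measured compounds, a step that the two limits leave unreadable from compound 1 to compound 2, is therefore not readable in size, since (the limit of > 20000 nM in this assay, at which 3 of the 3 values shown sit).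

Compound 4 `Nc1cc(Br)ccc1NC(=O)c1ccc(CNc2nccc(-c3cccnc3)n2)cc1` changes the same ring position: a group of 8 heavy atoms (6 carbon, 1 nitrogen, 1 bromine; one six-membered aromatic ring of carbon only) in place of a group of 11 heavy atoms (10 carbon, 1 nitrogen; 2 six-membered aromatic rings of carbon only), on an amide-type nitrogen. For the measured compounds named here, no measured step bears on this change, because the limit of > 20000 nM in this assay, at which 3 of the 3 values shown sit, leaves every value at the limit, so no direction or size can be drawn from the measured steps. The expected step is a step that the limit leaves unreadable from compound 3 to compound 4, which is essentially none beyond the scatter. For compound 4 the estimated value in this assay is 25000 nM, with a range from 8000 nM to 80000 nM, most likely reported again only as a limit.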

Compound 4, half-maximal inhibitory concentration: > 20000 nM
Compound 4 was reported as a limit (the forecaster's own chance of this, stated with the estimate: 75%); the middle value is on the limit's open side.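

Compound 4, like compound 1, compound 2 and compound 3, stands only at a limit in this assay, so none of the steps to compound 4 can be read: the limit of > 20000 nM in this assay, at which 4 of the 4 values shown sit.

The compounds shown leave open which change to the shared core, if any, would give a value that is not a limit.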